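Hydroxyphenyl amide in place of the dibromophenyl amide

A few compounds are considered here, and "the series" means these few. Any claim that something is new, unique, unknown or untested is made for them only; others in the source may bear on it.

Compound 1 `O=C(Nc1ccc(Sc2nc3ccccc3s2)c(Cl)c1)c1cc(Br)cc(Br)c1` is assessed in an assay on isolated protein for inhibition of thiosulfate sulfurtransferase (Homo sapiens), with a stated time of 60 min, in the absence of a further agent; a higher number here means a weaker inhibitor, a lower number a stronger inhibitor. In this assay compound 1 gives only a limit, > 100000 nM. Compound 2 `O=C(Nc1ccc(Sc2nc3ccccc3s2)cc1)c1cc(Br)cc(Br)c1` likewise gives only a limit in this assay, > 100000 nM. Compound 3 `O=C(Nc1cccc(Cl)c1)c1cccc(Br)c1O` also gives only a limit in this assay, > 100000 nM. Among the measured compounds shown here, the single one-point step recorded, a step that the two limits leave unreadable from compound 1 to compound 2, is therefore unreadable, and the limit of > 100000 nM in this assay, at which 3 of the 3 values shown sit, is where every value so far sits. Compound 4 `O=C(Nc1ccc(Sc2nc3ccccc3s2)c(Cl)c1)c1ccccc1O` differs from compound 1 by 2-hydroxyphenyl in place of 3,5-dibromophenyl on a carbonyl carbon. For the measured compounds named here, no measured step bears on this change; compound 3, the only hydroxyl-bearing benzamide measured, sits at the limit as well, so no movement beyond the scatter is expected, the expected step being a step that the limit leaves unreadable from compound 1 to compound 4. Compound 4 is estimated at 150000 nM, within 40000 nM to 600000 nM, most probably reported again as a limit.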

Compound 4, half-maximal inhibitory concentration: > 100000 nM
Compound 4 was reported as a limit; the forecaster's own chance of this, stated with the estimate: 80%; the middle value is on the limit's open side.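

Compound 1 and compound 4 both give only limits in this assay, so no step between them can be read: the limit of > 100000 nM in this assay, at which 4 of the 4 values shown sit.

The compounds shown leave open which structural change, if any, would give a numerical value in this assay.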